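Swapping the aryl group on a sulfonamide-amine chain

A few compounds are considered here, and "the series" means these few. Any claim that something is new, unique, unknown or untested is made for them only; others in the source may bear on it.

Two measured compounds share a bis(trifluoromethyl)benzenesulfonamide joined through a short diamine chain to a benzyl-type group. In a functional assay on HPAC cells (Homo sapiens) for inhibition, read by MTT assay, with a stated time of 72 h (a higher number here means a weaker inhibitor of growth, a lower number a stronger inhibitor of growth), compound 1 `CC(C)(C)c1ccc(CNCCCNS(=O)(=O)c2cc(C(F)(F)F)cc(C(F)(F)F)c2)cc1` gives 2300 nM. Compound 2 `O=S(=O)(NCCNCc1ccc(-c2ccccc2)cc1)c1cc(C(F)(F)F)cc(C(F)(F)F)c1`, whose chain is one carbon shorter and whose aryl group is a biphenyl, gives 2800 nM in this assay. Of the two figures, that of compound 1 is the lower, but the gap to compound 2 lies within the scatter, so the two compounds cannot be ranked against each other.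

Compound 3 `O=S(=O)(NCCCNCC1COc2ccccc2O1)c1cc(C(F)(F)F)cc(C(F)(F)F)c1` keeps the chain length of compound 1 and alters only the group at its end: 2,3-dihydro-1,4-benzodioxin-2-yl in place of 4-(tert-butyl)phenyl on a saturated chain carbon bound to an amine nitrogen. For the measured compounds named here, no measured pair shows this kind of exchange, so its effect is unknown. Because compound 1 gives 2300 nM and compound 2 gives 2800 nM with quite different aryl groups, a move of modest size, toward a higher number, is expected for compound 3 in this assay, and the step from compound 1 to compound 3 is estimated at a 1.7-fold higher number from compound 1 to compound 3 (0.24 log units; within the scatter). Compound 3 is expected to give 4000 nM, within a range from 1500 nM to 12000 nM.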

Compound 3, concentration for 50% growth inhibition: 2700 nM
Estimate against measurement, compound 3: 1.5-fold (0.17 log units) above; the measured number falls inside the stated range.
By their numbers in this assay, from the lowest: compounds 1, 3 and 2 (each within the scatter of the next).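

For the compounds shown here, compound 3 provides the first measured exchange at this position with the chain of compound 1 held constant: in this assay, 2,3-dihydro-1,4-benzodioxin-2-yl in place of 4-(tert-butyl)phenyl gives a 1.2-fold higher number from compound 1 to compound 3 (0.07 log units; within the scatter). The two groups have the same count of 10 heavy atoms, but the entering group brings 2 oxygen atoms, 2 hydrogen-bond acceptors and a six-membered non-aromatic ring, and compound 1 and compound 3 still cannot be told apart. On a saturated chain carbon bound to an amine nitrogen, this one exchange therefore produces no readable difference in growth inhibition, and no supporting measurement is available to explain that result.

Going by these compounds, whether this tolerance extends to other end groups, such as a carboxylic acid or a pyridine ring, remains open, since only these two groups have been compared on this chain. On these data alone, the effect of chain length alone also remains open, as compound 2 differs from compound 1 in both chain and aryl group, and a longer chain carrying the same end group would be needed to separate the two changes.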